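Methoxy to Hydrogen on a Rearranged Core

The source may hold more compounds than are shown below. What is called first, only, known or untested is meant among the compounds shown, and "the series" means these compounds.

Compound 1 `COc1ccc(-c2nc(C)c(C(=O)CSc3nc(N)c(C#N)c(-c4ccc(Cl)cc4)n3)s2)cc1` and compound 2 `Cc1nc(-c2ccccc2)sc1C(=O)CSc1nc(N)c(C#N)c(-c2ccc(Cl)cc2)n1` share one core and differ by one change, (hydrogen in place of methoxy on an aromatic carbon). In an assay on membranes from CHO cells for displacement of a labelled ligand from adenosine receptor A1 (Homo sapiens), read by scintillation counting, with a stated time of 60 min, tested at 1 uM (on this read-out lower numbers stand for less inhibition and higher numbers for more inhibition at the one concentration tested (going by the name of the read-out)), compound 1 gives 1.1%, and compound 2 gives -23%; the step of a number 24.1 percentage points lower from compound 1 to compound 2 (beyond the scatter). Compound 3 `COc1ccc(-c2nc(SCC(=O)c3sc(-c4ccc(Cl)cc4)nc3C)nc(N)c2C#N)cc1` is built from the same atoms as compound 1 joined differently; the difference between the two cores is not broken down here. In this assay compound 3 gives 1.2%, within the scatter of compound 1. Compound 4 `Cc1nc(-c2ccc(Cl)cc2)sc1C(=O)CSc1nc(N)c(C#N)c(-c2ccccc2)n1` differs from compound 3 by hydrogen in place of methoxy on an aromatic carbon, the same change seen between compound 1 and compound 2. Because the earlier step of a number 24.1 percentage points lower from compound 1 to compound 2 (beyond the scatter) went down, a similar downward step is expected here, though on a different core it is less certain, and the expected step is a number 16.2 percentage points lower from compound 3 to compound 4 (beyond the scatter). Compound 4 is estimated at -15%, between -35% and 5%.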

Compound 4, a percentage reported as inhibition, at one concentration (the size of the read-out at that concentration, not a potency): 8.7%
The estimate for compound 4 lay 23.7 percentage points below the measured number; the whole stated range lies below it.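

In this assay, putting hydrogen in place of methoxy gives a number 7.5 percentage points higher from compound 3 to compound 4 (within the scatter), so the fall seen on the core of compound 1 does not reappear on the core of compound 3. The two steps do not agree: the same change on two cores in this assay, a number 24.1 percentage points lower (beyond the scatter) from compound 1 to compound 2 and a number 7.5 percentage points higher (within the scatter) from compound 3 to compound 4, 31.6 percentage points apart, beyond the scatter of two such steps. This shows that, in this series, the result of this change on one core is a poor guide to its result on the other, but two pairs tested at one concentration do not show why the steps differ or how the change would behave on any further core.

Still open, on these data alone, is how an amine or a carboxylic acid at the same place would read on each core. As far as these compounds go, a longer chain such as ethoxy in place of methoxy is equally open.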